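Extending the carboxamide terminus of compound 2

This account rests on a few compounds, and the source may have more. Where it says the series, first, only, none or still open, it means among the compounds named here.

Measured compounds:
compound 1 `CC(C)C[C@H](NC(=O)CNC(=O)CC[C@H](NS(=O)(=O)c1ccc(Cl)c(C(F)(F)F)c1)C(=O)O)C(=O)N[C@H](C(=O)N[C@@H](C)C(N)=O)C(C)C`: 16 nM
compound 2 `CC(C)C[C@H](NC(=O)CNC(=O)CC[C@H](NS(=O)(=O)c1ccc(Cl)c(C(F)(F)F)c1)C(=O)O)C(=O)N[C@H](C(N)=O)C(C)C`: 56 nM

In an assay on isolated protein for inhibition of Matrilysin (Homo sapiens), read by fluorescence, with a stated time of 15 min (on this read-out lower numbers stand for stronger inhibition and higher numbers for weaker inhibition), compound 1 gives 16 nM, while compound 2 gives 56 nM. Compound 2 therefore stands at the highest of the two numbers, its nearest neighbour being compound 1. Within the data shown here, the single step between them, a 3.5-fold higher number from compound 1 to compound 2 (0.54 log units; beyond the scatter), followed the loss of the terminal 1-carbamoylethyl group.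

Compound 3 `CC(C)C[C@H](NC(=O)CNC(=O)CC[C@H](NS(=O)(=O)c1ccc(Cl)c(C(F)(F)F)c1)C(=O)O)C(=O)N[C@H](C(=O)N1CCC[C@H]1CC(N)=O)C(C)C` differs from compound 2 by 2-(carbamoylmethyl)pyrrolidin-1-yl in place of amino on a carbonyl carbon. This re-extends the terminus that was shortened in a 3.5-fold higher number from compound 1 to compound 2 (0.54 log units; beyond the scatter), now with a ring-bearing carboxamide rather than the open 1-carbamoylethyl of compound 1. Among the measured compounds shown here, only that one step bears on the change; it was modest. A partial return toward the number of compound 1 is expected, a modest downward step a 2.0-fold lower number from compound 2 to compound 3 (0.30 log units; within the scatter). Compound 3 is estimated at 28 nM, within 10 nM to 80 nM.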

Compound 3, half-maximal inhibitory concentration: 10 nM
Compound 3: the middle estimate sits 2.8-fold (0.45 log units) above what was measured, within the range that was stated.
By their numbers in this assay, from the lowest: compounds 3 and 1 (each within the scatter of the next); then compound 2.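

Working notes: at this carbonyl carbon, a 5.6-fold lower number from compound 2 to compound 3 (0.75 log units; beyond the scatter) in this assay when amino gives way to 2-(carbamoylmethyl)pyrrolidin-1-yl, so the position accepts a five-membered non-aromatic ring as well as the open chain of compound 1. The ring-bearing and open extensions are not separated here, with a 1.6-fold lower number from compound 1 to compound 3 (0.20 log units; within the scatter) on going from (1-carbamoylethyl)amino to 2-(carbamoylmethyl)pyrrolidin-1-yl, and both compound 1 and compound 3 stand apart from the shorter compound 2. No measurement shown accounts for these steps.

Still open, from the compounds shown here alone, is whether the terminal carboxamide matters, which a carboxylic acid or a methyl ester in its place would address. Also open, going by these compounds, is what the carbamoylmethyl arm contributes, as plain pyrrolidin-1-yl on the same carbonyl carbon would show.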